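Side-chain change from compound 2 to compound 3

The source may hold more compounds than are shown below. What is called first, only, known or untested is meant among the compounds shown, and "the series" means these compounds.

compound 1 `CCOC(=O)CO/N=C(\c1ccc(SC)cc1)c1cccc2ccccc12`: 30000 nM
compound 2 `CCCCN(C)CCCO/N=C(\c1ccc(SC)cc1)c1cccc2ccccc12`: > 50000 nM (a limit)

In a functional assay on MCF7 cells (Homo sapiens) for antiproliferative activity, read by MTT assay, with a stated time of 24 h (on this read-out higher numbers stand for an effect only at larger amounts of compound and lower numbers for an effect already at smaller amounts), compound 2 has no number, only a limit: the limit of > 50000 nM in this assay, at which 1 of the 2 values shown sits. The change to compound 3 `CSc1ccc(/C(=N\OCCCCN2CCCCC2)c2cccc3ccccc23)cc1` is (piperidin-1-yl)methyl in place of butyl(methyl)amino on a saturated chain carbon, three bonds along the chain from an oxygen on an unsaturated carbon, with (piperidin-1-yl)methyl in place of butyl(methyl)amino on a saturated chain carbon. Among the compounds with values here, the one measured step that bears on it is an at least 1.6-fold higher number from compound 1 to compound 2 (0.22 log units; that floor lies within the scatter), which gives no size beyond the scatter. No shift beyond the scatter is therefore expected, and the estimated step is a number no higher from compound 2 to compound 3 (the limit leaves the size open). The estimate for compound 3 is 50000 nM, with an expected range of 20000 nM to 120000 nM.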

Compound 3, half-maximal effective concentration: 8000 nM
Compound 3: middle estimate off by 6.3-fold (0.80 log units), on the high side; measured number below the stated range.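

Putting (piperidin-1-yl)methyl in place of butyl(methyl)amino at this place gives an at least 6.2-fold lower number from compound 2 to compound 3 (0.79 log units; beyond the scatter) in this assay, so a side chain ending in an amine is not poor in itself. Against the ester, 3-(piperidin-1-yl)propyl in place of ethoxycarbonyl gives a 3.8-fold lower number from compound 1 to compound 3 (0.57 log units; beyond the scatter). The first size remains a floor because compound 2 carries only a limit: the limit of > 50000 nM in this assay, at which 1 of the 3 values shown sits.

The ring and the chain length change together, so the compounds shown do not separate them. On these data alone, a morpholine or dimethylamino group on the same chain remains open.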